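Adding a Methyl Beside the Linker Carbonyl of Compound 2

The source may report more compounds than this note shows. Statements on the series, on what has been measured and on what is new or still open speak of the compounds shown alone.

Of the compounds shown here, three have been measured in a functional assay on HT-29 cells (Homo sapiens) for cytotoxicity, read by MTT assay, with a stated time of 48 h; a higher number here means a weaker inhibitor, a lower number a stronger inhibitor. Compound 1 `CCn1c(=O)ccn(C2OC(Cn3cc(COC(=O)C(C)NC(=O)C(C)n4cnc5c4c(=O)n(C)c(=O)n5C)nn3)C(O)C2O)c1=O` gives 2710 nM, compound 2 `CCn1c(=O)ccn(C2OC(Cn3cc(COC(=O)Cn4cnc5c4c(=O)n(C)c(=O)n5C)nn3)C(O)C2O)c1=O` gives 2190 nM, and compound 3 `Cn1c(=O)c2c(ncn2CC(=O)NCc2cn(CC3OC(n4ccc(=O)[nH]c4=O)C4OC(C)(C)OC34)nn2)n(C)c1=O` gives 58200 nM. Compound 2 stands at the low end of these three numbers; compound 1 lies within the scatter of it, so the two cannot be told apart, while compound 3 lies well beyond the scatter. Compound 4 `CCn1c(=O)ccn(C2OC(Cn3cc(COC(=O)C(C)n4cnc5c4c(=O)n(C)c(=O)n5C)nn3)C(O)C2O)c1=O` is not yet measured. It differs from compound 2 by methyl in place of hydrogen on a saturated chain carbon bound to an aromatic nitrogen and a carbonyl carbon. Among the compounds with values here, no measured pair shows this kind of change, so in this assay a step from compound 2 to compound 4 of a 1.1-fold higher number from compound 2 to compound 4 (0.02 log units; within the scatter) is expected, which is no step beyond the scatter. Compound 4 is therefore estimated at 2300 nM, with a range from 900 nM to 6000 nM.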

Compound 4, half-maximal inhibitory concentration: 62800 nM
For compound 4 the middle estimate is 27-fold (1.44 log units) below the measured one; measured number above the stated range.
By their numbers in this assay, from the lowest: compounds 2 and 1 (each within the scatter of the next); then compounds 3 and 4 (each within the scatter of the next).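

In this assay this position proves far from indifferent: methyl in place of hydrogen on a saturated chain carbon bound to an aromatic nitrogen and a carbonyl carbon gives a large step (a 29-fold higher number from compound 2 to compound 4 (1.46 log units; beyond the scatter)) and a much weaker inhibitor. Within the data shown here, the earlier compounds offered no pair differing in one place, so this is the first reading of how sensitive this carbon is. Nothing given here explains the step.

As far as these compounds go, it remains open whether ethyl or a hydroxyl group on this carbon would weaken the compound to a similar degree. From the compounds shown here alone, it is also open whether methyl has the same effect on this carbon in compound 1.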